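The compounds below may be only part of what the source reports. "The series", "measured", "known", "first", "only" and "open" are said of these compounds alone.

Measured compounds in a physicochemical assay for solubility, with a stated time of 18 h, at pH 7.4; a higher number here means a more soluble compound, a lower number a less soluble compound:

Compound 1, `COc1cccc(CNCCCNc2ccnc3cc(Oc4ccc(F)cc4)ccc23)c1O` — 14500 nM
Compound 2, `COc1cccc(CNCCCNc2ccnc3cc(-c4cccc5ccccc45)ccc23)c1O` — 32000 nM
Compound 3, `COc1cccc(CNCCCNc2ccnc3cc(CC(C)C)ccc23)c1O` — 4200 nM

Compound 3 gives the lowest number of the three in this assay: a 3.5-fold lower number from compound 1 to compound 3 (0.54 log units; beyond the scatter) and a 7.6-fold lower number from compound 2 to compound 3 (0.88 log units; beyond the scatter), both beyond the scatter. Compound 4, `COc1cccc(CNCCCNc2ccnc3cc(CCc4ccccc4)ccc23)c1O`, is not yet measured. Its change from compound 3 is benzyl in place of isopropyl on a saturated chain carbon bound to an aromatic carbon.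

The two steps that bear on it both end at compound 3 and both replace a group with a ring by isobutyl, the step from compound 1 being the smaller and the step from compound 2 the larger. Compound 4 reverses the direction: a benzyl enters where isopropyl sat. Taken together with the values of compound 1 and compound 2, an increase of modest size in this assay is expected for compound 4, roughly of the order seen for compound 1, since the phenethyl of compound 4 is not one of the measured groups and no step between it and 4-fluorophenoxy or naphthalen-1-yl is available. The expected step is a 2.6-fold higher number from compound 3 to compound 4 (0.42 log units; beyond the scatter). The estimate for compound 4 is therefore 11000 nM, with a range from 4500 nM to 27000 nM.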

Compound 4, solubility: 4200 nM
For compound 4 the middle estimate is 2.6-fold (0.42 log units) above the measured one; the measured number lies below the stated range.
By their numbers in this assay, from the lowest: compounds 3 and 4 (each within the scatter of the next); then compound 1; then compound 2.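

In this assay, phenethyl in place of isobutyl gives no change at the digits printed from compound 3 to compound 4 (within the scatter), so a six-membered aromatic ring of carbon only, carried at the end of this saturated chain, does not separate compound 4 from compound 3. The earlier compounds shown here alone could be read as placing ring-bearing groups on this aromatic carbon above isobutyl, but compound 4 goes against that reading, with a 3.5-fold lower number from compound 1 to compound 4 (0.54 log units; beyond the scatter) and a 7.6-fold lower number from compound 2 to compound 4 (0.88 log units; beyond the scatter). No supporting data accompany this result to account for it.

From the compounds shown here alone, what sets 4-fluorophenoxy and naphthalen-1-yl apart from phenethyl at this position remains open. Going by these compounds, it is also open how an amine, a carboxylic acid or a longer chain ending in a phenyl ring would read in this assay at this position.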